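Sulfur-linked aryl urea series: relocating the phenyl group

This account rests on a few compounds, and the source may have more. Where it says the series, first, only, none or still open, it means among the compounds named here.

Measured compounds:
compound 1 `CCCCCCCN(CCCCCSc1cc(-c2ccccc2)c(-c2ccccc2)nn1)C(=O)Nc1ccc(F)cc1F`, 75%
compound 2 `CCCCCCCN(CCCCCSc1cc(-c2ccccc2)cnn1)C(=O)Nc1ccc(F)cc1F`, 75%

In an assay on microsomes from liver for inhibition of sterol O-acyltransferase 1 (Rattus norvegicus), tested at 50 ug/mL (a lower number here means less inhibition, a higher number more inhibition at the concentration tested (going by the name of the read-out)), compound 1 gives 75% and compound 2 gives 75%. Among the measured compounds shown here, the only measured step, no change at the digits printed from compound 1 to compound 2 (within the scatter), shows that removing one phenyl from the aromatic ring leaves the read-out untouched within the scatter. For the measured compounds named here, compound 2 therefore stands level with compound 1 on the numbers available, with no measured compound differing from it beyond the scatter.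

Compound 3 `CCCCCCCN(CCCCCSc1ccc(-c2ccccc2)nn1)C(=O)Nc1ccc(F)cc1F` is the next target. The change from compound 2 is a group of 12 heavy atoms (10 carbon, 2 nitrogen; one six-membered aromatic ring of carbon only, one six-membered aromatic ring with 2 hetero atoms) in place of a group of 12 heavy atoms (10 carbon, 2 nitrogen; one six-membered aromatic ring of carbon only, one six-membered aromatic ring with 2 hetero atoms), on a sulfur. Going by the values given here, the single measured step bears on this only indirectly, since it concerns loss of a phenyl rather than a rearrangement of the same atoms; its size was nil within the scatter. Among the compounds with values here, on that basis the step of a number 5 percentage points lower from compound 2 to compound 3 (within the scatter) is expected to be none beyond the scatter, with the uncertainty widened because no measured pair rearranges the phenyl in this way. Compound 3 is estimated at 70%, in the range 45% to 90%.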

Compound 3, a percentage reported as inhibition, at one concentration (the size of the read-out at that concentration, not a potency): 44%
Estimate against measurement, compound 3: 26 percentage points above; measured number outside the range, below it.
By their numbers in this assay, from the lowest: compound 3; then compounds 1 and 2 (each within the scatter of the next).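

In this assay the same atoms joined differently do not behave alike, with a number 31 percentage points lower from compound 2 to compound 3 (beyond the scatter). Hydrogen in place of phenyl on an aromatic carbon gives a number 31 percentage points lower from compound 1 to compound 3 (beyond the scatter), whereas the same kind of change gave no change at the digits printed from compound 1 to compound 2 (within the scatter), so among these three compounds the outcome depends on which phenyl is lost. No available data explain this difference.

Still open, from the compounds shown here alone, is whether the 6-phenylpyridazin-3-yl group of compound 3 would keep this level if a methyl, a methoxy or an amine replaced its phenyl, or if the phenyl carried a fluorine. The read-out also stands at a single concentration, leaving open how far the gap between these compounds reflects a difference in potency.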